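The source may report more compounds than this note shows. Statements on the series, on what has been measured and on what is new or still open speak of the compounds shown alone.

Measured compounds:
compound 1 `CC(C)Cc1ccc2c(NCCCNCc3ccco3)ccnc2c1`, a physicochemical assay for acid dissociation, 9.47
compound 2 `COc1cccc(Oc2ccc3c(NCCCNCc4cc(F)ccc4OC)ccnc3c2)c1`, this assay 9.28
compound 3 `COc1cccc(Oc2ccc3c(NCCCNCc4cccc(OC)c4O)ccnc3c2)c1`, this assay 9.28

Compound 2 stands level with compound 3 at the digits shown, the two together giving the lowest of the three numbers; compound 1 lies higher only within the scatter. The step to compound 4 `COc1ccc(F)cc1CNCCCNc1ccnc2cc(-c3ccccc3)ccc12` is phenyl in place of 3-methoxyphenoxy on an aromatic carbon. For the measured compounds named here, the one measured step, no change at the digits printed from compound 2 to compound 3 (within the scatter), alters the group on the saturated chain carbon bound to an amine nitrogen, not the core, so it bears on this change only loosely. Compound 1 differs from compound 2 in more than one place, the core carbon among them, and their values sit within the scatter of each other. The step of a number 0.07 log units higher from compound 2 to compound 4 (within the scatter) is therefore expected to stay within the scatter. Compound 4 is estimated at 9.35, with a range from 9.1 to 9.6.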

Compound 4, acid dissociation constant: 9.47
Compound 4: the middle estimate sits 0.12 log units below what was measured, within the range that was stated.
By their numbers in this assay, from the lowest: compounds 2, 3, 1 and 4 (each within the scatter of the next).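

In this assay, for the compounds shown here, phenyl in place of 3-methoxyphenoxy on this aromatic carbon gives a number 0.19 log units higher from compound 2 to compound 4 (within the scatter) and is the first step read at this position. The 9 heavy atoms and 2 hydrogen-bond acceptors of 3-methoxyphenoxy give way to the 6 heavy atoms and 0 acceptors of phenyl, and the read-out does not separate the two groups. Nothing on hand accounts for the step. Open still is whether an amine or a carboxylic acid on this carbon would stay within the scatter of compound 2.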